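The source may report more compounds than this note shows. Statements on the series, on what has been measured and on what is new or still open speak of the compounds shown alone.

Measured in a functional assay on U-937 cells (Homo sapiens) for antiproliferative activity, read by CCK-8 assay, with a stated time of 24 h; on this read-out lower numbers stand for stronger inhibition and higher numbers for weaker inhibition:

- Compound 1 `C/C(=N\NC(=O)Nc1nc2ccc(CN(C)C)cc2s1)c1cnccn1`: > 40000 nM (a limit)
- Compound 2 `CCN(CC)Cc1ccc2nc(NC(=O)N/N=C/c3ccccn3)sc2c1`: 24800 nM
- Compound 3 `CCN(CC)Cc1ccc2nc(NC(=O)N/N=C(\C)c3ccccn3)sc2c1`: 15600 nM

Compound 3 gives 15600 nM and sits within the scatter of compound 2, as the measured change a 1.6-fold lower number from compound 2 to compound 3 (0.20 log units; within the scatter) shows. Compound 1 is reported only as a limit, > 40000 nM.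

Compound 4 `CCN(CC)Cc1ccc2nc(NC(=O)N/N=C(\C)c3cnccn3)sc2c1` carries pyrazin-2-yl in place of pyridin-2-yl on a carbon with a double bond to nitrogen. Among the compounds with values here, no measured step makes this exchange directly. Within the data shown here, the one step available, a 1.6-fold lower number from compound 2 to compound 3 (0.20 log units; within the scatter), is a different change and stays within the scatter, so it gives no direction. Among the measured compounds shown here, the only hint comes from compound 1, which also carries pyrazin-2-yl and stands at the limit > 40000 nM. This points weakly towards a higher number in this assay, though no step beyond the scatter can be expected with confidence. The expected step is a 1.6-fold higher number from compound 3 to compound 4 (0.20 log units; within the scatter). Compound 4 is estimated at 25000 nM, with an expected range of 10000 nM to 55000 nM.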

Compound 4, half-maximal inhibitory concentration: > 40000 nM
Compound 4: no number, only a limit; the forecaster's own chance of this, stated with the estimate: 30%; middle value at least 1.6-fold (0.20 log units) from the limit.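

In this assay, within the data shown here, pyrazin-2-yl in place of pyridin-2-yl on a carbon with a double bond to nitrogen gives the first step at this position that lies beyond the scatter: an at least 2.5-fold higher number from compound 3 to compound 4 (0.40 log units; beyond the scatter). On these data alone, compound 4 is reported only as a limit, so this step is a floor and its full size stays unknown: the limit of > 40000 nM in this assay, at which 2 of the 4 values shown sit. The reading against compound 2 is less firm, an at least 1.6-fold higher number from compound 2 to compound 4 (0.20 log units; that floor lies within the scatter), and the two limits leave the step from compound 1 to compound 4 unreadable.

The compounds shown leave open how phenyl or pyrimidin-2-yl would read at this place, and whether any group there would give a lower number than pyridin-2-yl does. They also leave open how a cyclic amine such as pyrrolidine would read in place of diethylamino.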